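This account rests on a few compounds, and the source may have more. Where it says the series, first, only, none or still open, it means among the compounds named here.

Measured in an ADME assay on A549 cells (Homo sapiens) for cytotoxicity, read by resazurin assay, with a stated time of 48 h; a lower number here means that less compound is tolerated, a higher number that more compound is tolerated:

Compound 1 `CC(=O)Nc1ccc(NC(=O)c2cc(Cl)ccc2O)c(Cl)c1` gives "not determined" (no result reported)
Compound 2 `CC1(Nc2ccc(NC(=O)c3cc(Cl)ccc3O)c(Cl)c2)CCCC1` gives 157000 nM
Compound 3 `O=C(Nc1ccc(NCc2ccc(O)cc2)cc1Cl)c1cc(Cl)ccc1O` gives 116000 nM

Compound 1 offers no number for comparison. Within the data shown here, compound 3 at 116000 nM and compound 2 at 157000 nM are the only two numbers available, and they lie within the scatter of each other, with a 1.4-fold lower number from compound 2 to compound 3 (0.13 log units; within the scatter) separating them.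

Compound 4 `O=C(Nc1ccc(NCc2cccnc2Cl)cc1Cl)c1cc(Cl)ccc1O` has not yet been measured. Its difference from compound 3 is 2-chloropyridin-3-yl in place of 4-hydroxyphenyl on a saturated chain carbon bound to a nitrogen on an aromatic ring; in words, 2-chloropyridin-3-yl stands in place of 4-hydroxyphenyl on a saturated chain carbon bound to a nitrogen on an aromatic ring.

Among the measured compounds shown here, only one measured step bears on this change. It put 4-hydroxybenzyl in place of 1-methylcyclopentyl on a nitrogen on an aromatic ring. For the measured compounds named here, no measured compound carries 2-chloropyridin-3-yl, so the data do not show directly what that group does here. Going by the values given here, with a 1.4-fold lower number from compound 2 to compound 3 (0.13 log units; within the scatter) as the sole guide, no step beyond the scatter is expected in this assay. The estimated step is a 1.3-fold lower number from compound 3 to compound 4 (0.11 log units; within the scatter), and a single precedent is thin evidence, so the range is set wide. Compound 4 is expected at 90000 nM, with an estimated range from 30000 nM to 200000 nM.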

Compound 4, half-maximal cytotoxic concentration: 101000 nM
For compound 4 the middle estimate is 1.1-fold (0.05 log units) below the measured one, and the stated range covers the measured number.
By their numbers in this assay, from the lowest: compounds 4, 3 and 2 (each within the scatter of the next).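

In this assay, putting 2-chloropyridin-3-yl in place of 4-hydroxyphenyl on a saturated chain carbon bound to a nitrogen on an aromatic ring gave a 1.1-fold lower number from compound 3 to compound 4 (0.06 log units; within the scatter), so at this position a ring with a hetero atom and a chlorine, carrying no hydrogen-bond donors, reads the same as the phenol within the scatter. The comparison with the 1-methylcyclopentyl compound, with (2-chloropyridin-3-yl)methyl in its place, gave a 1.6-fold lower number from compound 2 to compound 4 (0.19 log units; within the scatter), which means that all three groups on this nitrogen now stand within the scatter of one another in this assay. No measurement available here accounts for this result.

The chlorine and the ring nitrogen enter together, so the compounds shown cannot separate what each contributes, and compound 1 supplies no number against which the other three could be read. Going by these compounds, whether a carboxylic acid or a primary amine on this ring, or a longer chain in place of the saturated chain carbon, would give a step beyond the scatter remains open.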